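Efficacy notes: ethyl for methylsulfanyl, compound 2 to compound 4

The source may report more compounds than this note shows. Statements on the series, on what has been measured and on what is new or still open speak of the compounds shown alone.

Measured compounds:
Compound 1 `Cc1cccc(C(=O)NCN2CCC(c3ccccn3)CC2)c1`: 67%
Compound 2 `CSc1cccc(NC(=O)CN2CCC(c3cccc[n+]3[O-])CC2)c1`: 56%
Compound 3 `Cc1cccc(C(=O)NCN2CCC(c3nccs3)CC2)c1`: 71%

In a functional assay on HEK293 cells for agonist activity at D(4) dopamine receptor (Homo sapiens), read by FLIPR (a higher number here means a larger maximal response, a lower number a smaller maximal response), compound 2 stands lowest of the three; compound 1 with 67% and compound 3 with 71% both lie above it beyond the scatter. Compound 4 `CCc1cccc(NC(=O)CN2CCC(c3cccc[n+]3[O-])CC2)c1` differs from compound 2 by ethyl in place of methylsulfanyl on an aromatic carbon. Going by the values given here, the only measured step, a number 4 percentage points higher from compound 1 to compound 3 (within the scatter), concerns the group on the saturated ring carbon and not the 3-(methylsulfanyl)phenyl part, so it does not bear on this exchange. Among the compounds with values here, no measured step touches that phenyl ring, so no shift beyond the scatter is expected. The estimate for compound 4 in this assay is 56%, range 40% to 72%. The expected step is no change at the digits printed from compound 2 to compound 4 (within the scatter), within the scatter.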

Compound 4, largest response reached (reported as efficacy), in percent of the reference or control that the assay uses: 62%
For compound 4 the middle estimate is 6 percentage points below the measured one, and the stated range covers the measured number.
By their numbers in this assay, from the lowest: compounds 2, 4, 1 and 3 (each within the scatter of the next, the first and the last beyond it).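

In this assay, the first exchange shown on this phenyl ring gives a number 6 percentage points higher from compound 2 to compound 4 (within the scatter) as methylsulfanyl leaves and ethyl enters. At this aromatic carbon, meta to a large group, the sulfur and the hydrogen-bond acceptor counted with methylsulfanyl can therefore leave without a step beyond the scatter. No measurement at hand gives a cause for this step.

Going by these compounds, what a methoxy group, an amine or a longer chain such as propyl would do at this carbon stays open. So does whether the same exchange gives a similar step on the core of compound 1.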